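This account rests on a few compounds, and the source may have more. Where it says the series, first, only, none or still open, it means among the compounds named here.

In a functional assay on MCF7 cells (Homo sapiens) for antiproliferative activity, read by MTT assay (on this read-out lower numbers stand for stronger inhibition and higher numbers for weaker inhibition), compound 1 (`COc1cc2c(Oc3ccc(NC(=O)Nc4ccccc4Cl)cc3)ccnc2cc1OCCCCCCC(=O)NO`) stands at 2780 nM and compound 2 (`COc1cc2c(Oc3ccc(NC(=O)Nc4ccc(OC(F)(F)F)cc4)cc3)ccnc2cc1OCCCCCCC(=O)NO`) at 3200 nM while compound 3 (`COc1cc2c(Oc3ccc(NC(=O)Nc4ccc(Cl)c(C(F)(F)F)c4)cc3)ccnc2cc1OCCCCCCC(=O)NO`) stands at 5150 nM on the same read-out. Compound 3 thus lies within the scatter of both other compounds, and the three values cannot be placed in any order. Compound 4 (`COc1cc2c(Oc3ccc(NC(=O)NC4CCCCC4)cc3)ccnc2cc1OCCCCCCC(=O)NO`) has not yet been measured. It differs from compound 3 on the amide-type nitrogen whose other neighbour is the carbonyl carbon, as follows: cyclohexyl in place of 4-chloro-3-(trifluoromethyl)phenyl on an amide-type nitrogen (cyclohexyl in place of 4-chloro-3-(trifluoromethyl)phenyl). The measured steps that bear on this change are the exchanges of substituted phenyl groups at that same nitrogen. The first is a 1.2-fold higher number from compound 1 to compound 2 (0.06 log units; within the scatter) and the second is a 1.9-fold higher number from compound 1 to compound 3 (0.27 log units; within the scatter) and the third is a 1.6-fold higher number from compound 2 to compound 3 (0.21 log units; within the scatter) and each of them stays within the scatter. Going by the values given here, none of them replaces the aromatic ring with a non-aromatic one, so the data offer no direct precedent and the uncertainty is wide. On these small steps, no change beyond the scatter is expected in this assay for this exchange. The expected change is a 1.3-fold lower number from compound 3 to compound 4 (0.11 log units; within the scatter) and that estimate remains within the scatter. The expected value for compound 4 is 4000 nM (estimated range 1500 nM to 11000 nM).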

Compound 4, half-maximal inhibitory concentration: 600 nM
Compound 4: middle estimate off by 6.7-fold (0.82 log units), on the high side; the whole stated range lies above it.
By their numbers in this assay, from the lowest: compound 4; then compounds 1, 2 and 3 (each within the scatter of the next).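

In this assay, going by these compounds alone, cyclohexyl on the amide-type nitrogen is the first exchange at this position to move beyond the scatter: it gives an 8.6-fold lower number from compound 3 to compound 4 (0.93 log units; beyond the scatter) and also a 5.3-fold lower number from compound 2 to compound 4 (0.73 log units; beyond the scatter) and a 4.6-fold lower number from compound 1 to compound 4 (0.67 log units; beyond the scatter) with the same direction in all three steps. The three substituted phenyl groups could not be ordered among themselves, yet each stands apart from the non-aromatic ring, so among these four compounds the change of ring type matters more on this read-out than the choice of substituents on the phenyl ring. The data shown give no cause for this difference.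

From the compounds shown here alone, it remains open whether the lower number follows from the non-aromatic ring itself or from the loss of the substituents, and an unsubstituted phenyl or a cyclopentyl on this nitrogen would help separate the two. Also open, going by these compounds, is whether an open chain such as n-hexyl, or a piperidine ring carrying an amine, would keep the number of compound 4 on this read-out.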